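This account rests on a few compounds, and the source may have more. Where it says the series, first, only, none or still open, it means among the compounds named here.

Measured so far:
compound 1 `O=C1NC(c2ccc(Br)cc2)CN1S(=O)(=O)c1ccc(Cl)cc1`: 111000 nM
compound 2 `O=C1NC(c2ccccc2)CN1S(=O)(=O)c1ccc2c(c1)CCC2`: 2 nM

In a functional assay on SK-MEL-2 cells (Homo sapiens) for cytotoxicity (on this read-out lower numbers stand for stronger inhibition and higher numbers for weaker inhibition), compound 1 gives 111000 nM, the higher of the two numbers and so the weaker inhibitor of the pair. Compound 2 gives 2 nM, a far lower number. For the measured compounds named here, these two compounds differ in two places at once, so no single step connects them and the two values alone cannot say which part of the structure carries the gap.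

Compound 3 `O=C1NC(c2ccccc2)CN1S(=O)(=O)c1ccc(Cl)cc1` is compound 1 with one change: hydrogen in place of bromo on an aromatic carbon. Cut one bond further out, the change reads as 4-bromophenyl to phenyl. Compound 3 therefore carries the same plain phenyl as compound 2 while keeping the sulfonyl part of compound 1. The step of a 5.6-fold lower number from compound 1 to compound 3 (0.74 log units; beyond the scatter) is expected to run toward a lower number, of moderate size, with wide uncertainty. Compound 3 is estimated at 20000 nM, most likely between 500 nM and 120000 nM.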

Compound 3, half-maximal inhibitory concentration: 1430 nM
Estimate against measurement, compound 3: 14-fold (1.15 log units) above; the range from low to high includes it.
By their numbers in this assay, from the lowest: compound 2; then compound 3; then compound 1.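

In this assay, hydrogen in place of bromo on the aromatic carbon gives a 78-fold lower number from compound 1 to compound 3 (1.89 log units; beyond the scatter), a large step beyond the usual scatter, so a single atom at this position of the phenyl group strongly changes the number. The bromo group is still not the whole gap: compound 3 gives 1430 nM, while compound 2, with the same plain phenyl but a different sulfonyl part, gives 2 nM. Nothing available here explains why this change lowers the number.

Going by these compounds, it remains open whether the step is specific to bromo, since fluoro, methoxy or an amine at this position could give a very different number. On these data alone, it is also open whether the same change would have a step of similar size with the sulfonyl part of compound 2.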